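Indanylidene acetamides: amide swap from compound 1 to compound 3

The source may hold more compounds than are shown below. What is called first, only, known or untested is meant among the compounds shown, and "the series" means these compounds.

Measured so far:
compound 1, `CCNC(=O)/C=C1\CCc2ccc(F)cc21`: 63%
compound 2, `Cc1cccc2c1CC/C2=C\C(N)=O`: 13%

In a functional assay on the whole organism with Rattus norvegicus as the target, at a dose of 20 mg/kg by the oral route (on this read-out higher numbers stand for more inhibition at the one dose given (going by the name of the read-out) and lower numbers for less inhibition), compound 1 gives 63%, the higher of the two numbers in hand. Compound 2 gives 13% in this assay, a number well beyond the scatter below that of compound 1; the two differ in more than one place, so no single change is read from that gap.

Compound 3, `CON(C)C(=O)/C=C1\CCc2ccc(F)cc21`, differs from compound 1 in one place: methoxy(methyl)amino in place of ethylamino on a carbonyl carbon. Within the data shown here, no measured pair shows this particular change, so its effect is not anchored by any step in hand. Within the shared core of compound 1 only one amide variant has been measured, and the primary amide of compound 2 sits on a different core. The expectation is a moderate fall in this assay, from compound 1 to compound 3 of a number 21 percentage points lower from compound 1 to compound 3 (beyond the scatter), possibly beyond the scatter but with wide uncertainty. Compound 3 is estimated at 42%, in a range of 10% to 70%.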

Compound 3, a percentage reported as inhibition, in the whole organism at one dose (the size of the read-out at that dose, not a potency): 14%
Compound 3: middle estimate off by 28 percentage points, on the high side; low and high end bracket the measured number.
By their numbers in this assay, from the lowest: compounds 2 and 3 (each within the scatter of the next); then compound 1.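

Methoxy(methyl)amino in place of ethylamino on a carbonyl carbon gives, in this assay, a number 49 percentage points lower from compound 1 to compound 3 (beyond the scatter). Among these compounds, this is the first step that can be read as a single change, and it shows that this place alone can move the read-out well beyond the scatter. The swap gives up the hydrogen-bond donor of ethylamino and brings in a hydrogen-bond acceptor, but nothing in hand ties the fall to either of these.

On these data alone, it remains open how other groups on this carbonyl carbon compare with ethylamino on the core of compound 1, for instance propylamino or dimethylamino. Dimethylamino, with no amide hydrogen and no methoxy oxygen, would separate the loss of the donor from the entry of that oxygen.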